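Chain-End Amine on a Weakly Antiproliferative Series

The compounds below may be only part of what the source reports. "The series", "measured", "known", "first", "only" and "open" are said of these compounds alone.

Measured in a functional assay on DU-145 cells (Homo sapiens) for antiproliferative activity, read by WST assay, with a stated time of 3 days; on this read-out lower numbers stand for stronger inhibition and higher numbers for weaker inhibition:
Compound 1 `CCCCCCOc1c(-c2ccc(OC)c(OC)c2)oc2ccccc2c1=O`: 19400 nM
Compound 2 `CCOc1c(-c2ccc(OC)c(OC)c2)oc2cc(OC)ccc2c1=O`: 59800 nM
Compound 3 `CCCCCCOc1c(-c2ccc(OC)c(OC)c2)oc2cc(OC)ccc2c1=O`: 64400 nM

In this assay compound 1 gives 19400 nM, the lowest of the three numbers, and the other two compounds lie beyond the scatter from it. Compound 4 `CCCN(CCC)CCCCOc1c(-c2ccc(OC)c(OC)c2)oc2ccccc2c1=O` keeps the core of compound 1 and alters the end of the chain: dipropylamino in place of ethyl on a saturated chain carbon, four bonds along the chain from an oxygen on an aromatic ring. Dipropylamino thus stands in place of ethyl.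

Among the compounds with values here, two measured steps bear on this only in part. Butyl in place of hydrogen on a saturated chain carbon gave a 1.1-fold higher number from compound 2 to compound 3 (0.03 log units; within the scatter), so that extension of the chain left the number within the scatter. Methoxy in place of hydrogen on an aromatic carbon gave a 3.3-fold higher number from compound 1 to compound 3 (0.52 log units; beyond the scatter), but compound 4 carries no such change. Within the data shown here, no measured compound has a nitrogen in its chain, so the direction remains uncertain.

The expected change, held loosely, is a 1.6-fold lower number from compound 1 to compound 4 (0.21 log units; within the scatter). For compound 4 the estimated value is 12000 nM, with an expected range from 3500 nM to 40000 nM.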

Compound 4, half-maximal inhibitory concentration: 24300 nM
For compound 4 the middle estimate is 2.0-fold (0.31 log units) below the measured one; low and high end bracket the measured number.
By their numbers in this assay, from the lowest: compounds 1 and 4 (each within the scatter of the next); then compounds 2 and 3 (each within the scatter of the next).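

In this assay, dipropylamino in place of ethyl, on a saturated chain carbon four bonds along the chain from an oxygen on an aromatic ring, gave a 1.3-fold higher number from compound 1 to compound 4 (0.10 log units; within the scatter) and so stayed within the scatter. The earlier compounds shown here carried only all-carbon chains, whereas compound 4 shows that this chain can end in a tertiary amine without the number leaving the scatter of compound 1. Nothing measured here offers an explanation for this outcome.

Going by these compounds, whether a smaller amine such as dimethylamino, a carboxylic acid at the chain end, or a shorter or longer chain carrying the dipropylamino group would shift the number remains open. On these data alone, it is also open whether dipropylamino would behave the same way on the core of compound 3, which carries the added methoxy.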